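Taking the Nitro Group off Compound 3

The compounds below may be only part of what the source reports. "The series", "measured", "known", "first", "only" and "open" are said of these compounds alone.

In a functional assay on PC-3 cells (Homo sapiens) for inhibition, read by MTT assay, with a stated time of 48 h (on this read-out lower numbers stand for stronger inhibition and higher numbers for weaker inhibition), compound 1 `O=C(/C=C/c1ccccc1)c1ccc[nH]1` reads > 100000 nM, which is a limit of the assay and not a number. Compound 2 `O=C(/C=C/c1ccc(Cl)cc1)c1ccco1` gives 29000 nM. Compound 3 `O=C(/C=C/c1cccc([N+](=O)[O-])c1)c1ccco1` gives 14000 nM, the lower of the two actual numbers, and its gap to compound 2 lies just beyond the usual scatter.

Compound 4 `O=C(/C=C/c1ccccc1)c1ccco1` has yet to be measured. It has hydrogen in place of nitro on an aromatic carbon, a change counted as hydrogen in place of nitro on an aromatic carbon. For the measured compounds named here, no measured pair shows this change directly, so the guidance is indirect. Compound 1 has a bare six-membered aromatic ring, as compound 4 will, but a different second ring. Compound 1 reads > 100000 nM, which is again only a limit. Some loss of inhibition therefore seems likely, moderate rather than drastic, with a higher number in this assay. The expected change is a 2.5-fold higher number from compound 3 to compound 4 (0.40 log units; beyond the scatter). Compound 4 is estimated at 35000 nM, with an expected range from 12000 nM to 100000 nM.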

Compound 4, half-maximal inhibitory concentration: > 100000 nM
Compound 4 ended at the assay's limit; the forecaster's own chance of this, stated with the estimate: 20%; middle value at least 2.8-fold (0.45 log units) from the limit.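

In this assay hydrogen in place of nitro on this aromatic carbon gives an at least 7.1-fold higher number from compound 3 to compound 4 (0.85 log units; beyond the scatter) and so the bare ring does not keep the inhibition of compound 3. Hydrogen in place of chloro gives an at least 3.4-fold higher number from compound 2 to compound 4 (0.53 log units; beyond the scatter) and so compound 4 also falls behind compound 2, which means that in both pairs the ring with a substituent reads better than the bare ring. Both steps give only a minimum size, and the true gaps may be larger: the limit of > 100000 nM in this assay, at which 2 of the 4 values shown sit.

The step between compound 1 and compound 4 cannot be read, so the effect of furan-2-yl in place of 1H-pyrrol-2-yl stays unresolved. Also open, from the compounds shown here alone, is whether an amine or a methoxy group on this aromatic carbon would hold inhibition as nitro does or lose it as hydrogen does.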